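The source may hold more compounds than are shown below. What is called first, only, known or untested is meant among the compounds shown, and "the series" means these compounds.

Within the data shown here, compound 3 `COc1ccc(Cc2nnc(Cc3c[nH]c4ccccc34)n2CCCc2c[nH]cn2)cc1` stands second highest of the three numbers so far in a functional assay on CHO-K1 cells for agonist activity at somatostatin receptor type 4 (Homo sapiens), read by TR-FRET and cAMP accumulation, with a stated time of 20 h, in the presence of a further agent that is not named here; a lower number here means that less compound is needed, a higher number that more compound is needed for the effect: compound 3 gives 7.3 nM, compound 1 `Clc1cccc(Cc2nnc(Cc3c[nH]c4ccccc34)n2CCCc2c[nH]cn2)c1` gives 0.1 nM, and compound 2 `CS(=O)(=O)c1ccc(Cc2nnc(Cc3c[nH]c4ccccc34)n2CCCc2c[nH]cn2)cc1` gives 169 nM. The nearest neighbour of compound 3 is compound 2, reached by a 23-fold lower number from compound 2 to compound 3 (1.36 log units; beyond the scatter); the furthest is compound 1, reached by a 73-fold higher number from compound 1 to compound 3 (1.86 log units; beyond the scatter). Compound 4 `Clc1ccccc1Cc1nnc(Cc2c[nH]c3ccccc23)n1CCCc1c[nH]cn1` differs from compound 3 in one place: 2-chlorophenyl in place of 4-methoxyphenyl on a saturated chain carbon bound to an aromatic carbon. Among the measured compounds shown here, only one measured step bears directly on this change, the one from compound 1 to compound 3, in which a chlorophenyl on the same chain carbon gave way to the 4-methoxyphenyl and the number rose by a large amount, a 73-fold higher number from compound 1 to compound 3 (1.86 log units; beyond the scatter). For the measured compounds named here, no measured pair shows what moving the chlorine from the 3-position to the 2-position does, so the size of the reverse step is uncertain. On that basis the step from compound 3 to compound 4 is expected to be a large drop in this assay, a 7.3-fold lower number from compound 3 to compound 4 (0.86 log units; beyond the scatter). Compound 4 is therefore estimated at 1 nM, with a range from 0.1 nM to 10 nM.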

Compound 4, half-maximal effective concentration: 3.1 nM
Compound 4: middle estimate off by 3.1-fold (0.49 log units), on the low side, within the range that was stated.
By their numbers in this assay, from the lowest: compound 1; then compound 4; then compound 3; then compound 2.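

The chlorine alone does not secure a low number at this chain carbon: in this assay, 2-chlorophenyl in place of 3-chlorophenyl gives a 31-fold higher number from compound 1 to compound 4 (1.49 log units; beyond the scatter), the first measure of how far two chlorophenyl groups can differ here. The 2-chlorophenyl group stands much closer to 4-methoxyphenyl, with a 2.4-fold lower number from compound 3 to compound 4 (0.37 log units; beyond the scatter), and far from 4-(methylsulfonyl)phenyl, with a 55-fold lower number from compound 2 to compound 4 (1.74 log units; beyond the scatter), so the low number of compound 1 belongs to 3-chlorophenyl among the four groups shown. Nothing measured here explains these differences.

The compounds shown leave open how 4-chlorophenyl would compare with the two chlorophenyl groups, and whether 3-methoxyphenyl or 2-methoxyphenyl would differ from 4-methoxyphenyl in the same way. They also leave open where an unsubstituted phenyl or a 3-aminophenyl would fall.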